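Shortening the Side Chain: Methyl in Place of Isopropyl

The compounds below may be only part of what the source reports. "The series", "measured", "known", "first", "only" and "open" are said of these compounds alone.

Compound 1, `CSCC[C@H](NC(=O)CN(c1nc(Cl)nc2[nH]cnc12)C1CC1)C(=O)OCc1ccccc1`, gives 17.6% in a functional assay on the whole organism (Tail, strain ICR) with Mus musculus as the target, in the tail flick test, with a stated time of 150 min, at a dose of 25 umol/kg by the oral route; a higher number here means a stronger effect of the compound at the dose given, a lower number a weaker effect.
Compound 2, `O=C(CN(c1nc(Cl)nc2[nH]cnc12)C1CC1)N[C@@H](CCC(=O)OCc1ccccc1)C(=O)OCc1ccccc1`, gives 44.5% in this assay.
Compound 3, `CC(C)[C@H](NC(=O)CN(c1nc(Cl)nc2[nH]cnc12)C1CC1)C(=O)OCc1ccccc1`, gives 17.9% in this assay.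

Compound 3 stands second highest of these three. Its gap to compound 1 is within the scatter, a number 0.3 percentage points higher from compound 1 to compound 3 (within the scatter), whereas compound 2 lies beyond the scatter above it, a number 26.6 percentage points lower from compound 2 to compound 3 (beyond the scatter).

Compound 4, `C[C@H](NC(=O)CN(c1nc(Cl)nc2[nH]cnc12)C1CC1)C(=O)OCc1ccccc1`, is not yet measured. It differs from compound 3 by methyl in place of isopropyl on a saturated chain carbon bound to an amide-type nitrogen and a carbonyl carbon. Among the compounds with values here, both measured steps at this position bear on it: exchanging two small side chains gave a number 0.3 percentage points higher from compound 1 to compound 3 (within the scatter), while the larger benzyloxycarbonyl-bearing chain gave the one step beyond the scatter. Shrinking the group further is therefore expected to give at most a small step in this assay, if anything downward. Compound 4 is estimated at 15%, range 4% to 30%, a step of a number 2.9 percentage points lower from compound 3 to compound 4 (within the scatter) expected from compound 3.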

Compound 4, a percentage reported as activity, at one dose (the size of the read-out at that dose, not a potency): 23%
Compound 4: middle estimate off by 8 percentage points, on the low side, and the stated range covers the measured number.
By their numbers in this assay, from the lowest: compounds 1, 3 and 4 (each within the scatter of the next); then compound 2.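

In this assay, methyl in place of isopropyl stays within the scatter (a number 5.1 percentage points higher from compound 3 to compound 4 (within the scatter)), and methyl in place of 2-(methylsulfanyl)ethyl does too (a number 5.4 percentage points higher from compound 1 to compound 4 (within the scatter)). Among the compounds shown, only the 2-(benzyloxycarbonyl)ethyl chain stands apart from methyl (a number 21.5 percentage points lower from compound 2 to compound 4 (beyond the scatter)), so shortening the side chain to methyl does not lower the read-out beyond the scatter. No evidence here explains this outcome.

As far as these compounds go, whether the higher number of compound 2 requires the benzyloxycarbonyl group, or would also arise with a free carboxylic acid or a longer alkyl chain, remains open.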